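Swapping a Bulky Aryl Group for a Phenethyl Chain

The source may report more compounds than this note shows. Statements on the series, on what has been measured and on what is new or still open speak of the compounds shown alone.

Within the data shown here, compound 3 `COc1cccc(CNCCCNc2ccnc3cc(-c4ccc(C(C)(C)C)cc4)ccc23)c1O` gives the highest number of the three measured so far in an ADME assay for permeability, using PAMPA, with a stated time of 30 min, at pH 7.4 (a lower number here means that the compound crosses the layer more slowly, a higher number that the compound crosses the layer faster), namely 237 10^-6 cm/s. Compound 1 `COc1cccc(CNCCCNc2ccnc3cc(CCC(C)C)ccc23)c1O` gives 23 10^-6 cm/s, and compound 2 `COc1ccc(F)cc1CNCCCNc1ccnc2cc(CCc3ccccc3)ccc12` gives 23 10^-6 cm/s. Among the measured compounds shown here, the one measured step that bears on the change here is a 10-fold higher number from compound 1 to compound 3 (1.01 log units; beyond the scatter). Compound 4 `COc1cccc(CNCCCNc2ccnc3cc(CCc4ccccc4)ccc23)c1O` differs from compound 3 by phenethyl in place of 4-(tert-butyl)phenyl on an aromatic carbon. Compound 2 already carries a phenethyl group and sits at the lower end of the range, so undoing the gain seen from compound 1 to compound 3 seems the likely outcome. For compound 4 a drop of about a 7.9-fold lower number from compound 3 to compound 4 (0.90 log units; beyond the scatter) in this assay is therefore expected, giving an estimated 30 10^-6 cm/s, with a likely range from 12 10^-6 cm/s to 75 10^-6 cm/s.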

Compound 4, apparent permeability: 23 10^-6 cm/s
Compound 4: the middle estimate sits 1.3-fold (0.12 log units) above what was measured, and the stated range covers the measured number.
By their numbers in this assay, from the lowest: compounds 1, 2 and 4 (each within the scatter of the next); then compound 3.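

In this assay there is a 10-fold lower number from compound 3 to compound 4 (1.01 log units; beyond the scatter) with phenethyl in place of 4-(tert-butyl)phenyl, so the high number of compound 3 rests on the group at this aromatic carbon, not on the shared core. Phenethyl and isopentyl read alike here, with no change at the digits printed from compound 1 to compound 4 (within the scatter) for phenyl in place of isopropyl, and with no change at the digits printed from compound 2 to compound 4 (within the scatter) for 2-hydroxy-3-methoxyphenyl in place of 5-fluoro-2-methoxyphenyl. Nothing available gives a cause for these results. As far as these compounds go, whether the high number needs the tert-butyl group or only a phenyl ring bonded directly to the core stays open. So does the outcome with an amine or a carboxylic acid at this carbon.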